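Trimethoxyphenyl series: aryl swap on the saturated ring carbon

The source may hold more compounds than are shown below. What is called first, only, known or untested is meant among the compounds shown, and "the series" means these compounds.

Of the compounds shown here, two have been measured in a functional assay on PC-3 cells (Homo sapiens) for antiproliferative activity, read by MTT assay, tested at 1 uM; on this read-out lower numbers stand for a weaker effect and higher numbers for a stronger effect at the one concentration tested. Compound 1 `COc1cc(C2=NN(C(C)=O)C(c3c(Cl)cccc3Cl)O2)cc(OC)c1OC` gives 5.1% in this assay, the lowest of the two numbers. Going by the values given here, compound 2 `COc1cc(C(=O)N/N=C/c2ccc(Cl)c([N+](=O)[O-])c2)cc(OC)c1OC` gives 32.1% in this assay, a number that lies beyond the scatter above that of compound 1; the two structures differ in more than one place, so no single step between them is defined and only their two values can be set side by side.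

Compound 3 `COc1cc(C2=NN(C(C)=O)C(c3cccc(F)c3)O2)cc(OC)c1OC` has not yet been measured. It differs from compound 1 by 3-fluorophenyl in place of 2,6-dichlorophenyl on a saturated ring carbon. Among the compounds with values here, no step between measured compounds of this kind is known, so the size of the change cannot be read from a precedent. Compound 1 stands at 5.1%, near the bottom of the read-out. The step of a number 3.9 percentage points higher from compound 1 to compound 3 (within the scatter) is expected to be small and within the scatter, with somewhat more room upward than downward. Compound 3 is therefore estimated at 9% in this assay, with a range from 0% to 25%.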

Compound 3, a percentage reported as inhibition, at one concentration (the size of the read-out at that concentration, not a potency): 16.5%
The estimate for compound 3 lay 7.5 percentage points below the measured number, within the range that was stated.
By their numbers in this assay, from the lowest: compound 1; then compound 3; then compound 2.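

In this assay, going by these compounds alone, the swap on the saturated ring carbon gives a number 11.4 percentage points higher from compound 1 to compound 3 (beyond the scatter) and so provides the first readable step, showing that the aryl group at this place can move the read-out at this single concentration. The change is not a single substitution on the ring, since 3-fluorophenyl brings in fluorine while 2,6-dichlorophenyl takes away both chlorine atoms, so this one step cannot assign the rise to the loss of chlorine, the gain of fluorine or the different substitution pattern. Nothing measured on these compounds accounts for the step.

Still open, as far as these compounds go, is how these contributions divide: 3-chlorophenyl and unsubstituted phenyl on the same ring carbon, read against compound 1 and compound 3, would begin to separate them. Also open, from the compounds shown here alone, is whether the step holds with a group other than the acetyl group on the ring nitrogen, such as propanoyl, since both compounds carry acetyl there.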